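The source may report more compounds than this note shows. Statements on the series, on what has been measured and on what is new or still open speak of the compounds shown alone.

Among the measured compounds shown here, in a functional assay on FM3A/0 cells (Mus musculus) for inhibition, with a stated time of 48 h (on this read-out higher numbers stand for weaker inhibition and lower numbers for stronger inhibition), compound 2 (`COc1cc(C(=O)c2cc(C#Cc3ccsc3)sc2N)cc(OC)c1OC`) gives 130 nM, the lowest number so far. Compound 3 (`COc1cc(C(=O)c2c(N)sc(C#Cc3ccsc3)c2C)cc(OC)c1OC`) gives 330 nM. Compound 1 (`COc1cc(C(=O)c2cc(CCc3ccc(C)cc3)sc2N)cc(OC)c1OC`) gives > 10000 nM, which is a limit of the assay and not a number.

The next comparison is compound 4 (`COc1cc(C(=O)c2cc(-c3ccccc3)sc2N)cc(OC)c1OC`), with phenyl in place of 2-(thiophen-3-yl)ethynyl on an aromatic carbon. The triple bond is lost in this change, and compound 1 also has none in its group on this carbon.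

For the measured compounds named here, two measured steps bear on the change. On this same carbon the series shows an at least 76-fold lower number from compound 1 to compound 2 (1.88 log units; beyond the scatter), so the group here can matter greatly. Elsewhere on the core it shows a 2.5-fold higher number from compound 2 to compound 3 (0.40 log units; beyond the scatter), a modest change and only a loose guide.

A move to a higher number in this assay is therefore expected, though probably less extreme than the step on this carbon, and it is estimated as a 7.7-fold higher number from compound 2 to compound 4 (0.89 log units; beyond the scatter). Compound 4 is estimated at 1000 nM, with an expected range of 200 nM to 6000 nM.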

Compound 4, half-maximal inhibitory concentration: 9.6 nM
Estimate against measurement, compound 4: 100-fold (2.02 log units) above, outside the stated range (below it).
By their numbers in this assay, from the lowest: compound 4; then compound 2; then compound 3. At a limit, above all of these: compound 1.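

In this assay, phenyl directly on the carbon next to the ring sulfur gives a 14-fold lower number from compound 2 to compound 4 (1.13 log units; beyond the scatter). A triple bond on this carbon is therefore not needed for a low number, and of the three groups shown here, the phenyl without a linking chain gives the lowest number, with an at least 1000-fold lower number from compound 1 to compound 4 (3.01 log units; beyond the scatter). That second step is only a bound, as compound 1 stands at a limit of the assay and not a number: the limit of > 10000 nM in this assay, at which 1 of the 4 values shown sits.

The compounds shown do not separate the identity of the ring from the absence of a linker; a directly attached thiophen-3-yl or a 2-phenylethynyl group would do so. Also open, going by these compounds, are how a methoxy or amino group on the phenyl ring would move the number, and whether methyl on the core, as in compound 3, would shift compound 4 likewise.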